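The source may report more compounds than this note shows. Statements on the series, on what has been measured and on what is new or still open speak of the compounds shown alone.

Measured compounds in a functional assay on KG-1 cells (Homo sapiens) for cytotoxicity, read by luminescence and CellTiter-Glo, with a stated time of 3 days; on this read-out higher numbers stand for weaker inhibition and lower numbers for stronger inhibition:
- compound 1 `N#Cc1ccc(NC(=O)c2ccc(F)cc2O)cc1` gives 3150 nM
- compound 2 `N#Cc1ccc(NC(=O)c2cc(Br)ccc2O)cc1` gives 1290 nM
- compound 3 `N#Cc1ccc(NC(=O)c2ccc(-c3ccncc3)cc2O)cc1` gives 8840 nM

Compound 3 stands highest of the three numbers. Its gap to compound 1 and its gap to compound 2 are both beyond the scatter, so compound 3 is the weakest inhibitor of the three in this assay.

Compound 4 `N#Cc1ccc(NC(=O)c2ccccc2O)cc1` differs from compound 3 as follows: hydrogen in place of pyridin-4-yl on an aromatic carbon. The carbon concerned is meta to the hydroxy group and para to a large group. Among the compounds with values here, the single step that bears on this change is a 2.8-fold higher number from compound 1 to compound 3 (0.45 log units; beyond the scatter), where pyridin-4-yl arriving at this carbon raised the number. Taking pyridin-4-yl away is expected to undo most of that rise. Within the data shown here, no step from fluoro to hydrogen at this carbon is available, so whether compound 4 ends exactly level with compound 1 cannot be told; compound 2, with bromo elsewhere on the ring, does not bear directly on the change.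

Compound 4 is therefore expected to give a lower number than compound 3, a step of about a 2.5-fold lower number from compound 3 to compound 4 (0.40 log units; beyond the scatter). The estimate for compound 4 in this assay is 3500 nM, within a range of 1500 nM to 8000 nM.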

Compound 4, half-maximal inhibitory concentration: 5370 nM
For compound 4 the middle estimate is 1.5-fold (0.19 log units) below the measured one; low and high end bracket the measured number.
By their numbers in this assay, from the lowest: compound 2; then compounds 1, 4 and 3 (each within the scatter of the next, the first and the last beyond it).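

In this assay, within the data shown here, compound 4 supplies the hydrogen reference that the earlier compounds lacked at this carbon. Against that reference, a 1.6-fold lower number from compound 3 to compound 4 (0.22 log units; within the scatter) and a 1.7-fold higher number from compound 1 to compound 4 (0.23 log units; within the scatter) both lie within the scatter, so neither pyridin-4-yl nor fluoro at this carbon separates from hydrogen, even though the step between those two groups lies beyond it. Among these compounds, on a different ring carbon, bromo does separate from hydrogen, with a 4.2-fold higher number from compound 2 to compound 4 (0.62 log units; beyond the scatter) as the only step to compound 4 that lies beyond the scatter. No supporting data are available to explain these differences.

From the compounds shown here alone, it remains open whether bromo would separate from hydrogen at the carbon that carries fluoro and pyridin-4-yl. Going by these compounds, it is also open whether an amine or a carboxylic acid at that carbon would move the number beyond the scatter.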